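The compounds below may be only part of what the source reports. "The series", "measured", "known", "first", "only" and "open" are said of these compounds alone.

Working notes on the series.

Compound 1 `CN(C)CCCn1c(N)c(-c2nc3ccccc3[nH]2)c2nc(C#N)c(C#N)nc21` and compound 2 `CCN(CC)CCCn1c(N)c(-c2nc3ccccc3[nH]2)c2nc(C#N)c(C#N)nc21` share one core. In a functional assay on K562 cells (Homo sapiens) for antiproliferative activity, read by MTT assay, with a stated time of 48 h (on this read-out higher numbers stand for weaker inhibition and lower numbers for stronger inhibition), compound 1 gives 1730 nM and compound 2 gives 1800 nM. Within the data shown here, the single change between them, (diethylamino in place of dimethylamino on a saturated chain carbon, three bonds along the chain from an aromatic nitrogen), produced a 1.0-fold higher number from compound 1 to compound 2 (0.02 log units; within the scatter).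

Compound 3 `CN(C)CCCCn1c(N)c(-c2nc3ccccc3o2)c2nc(C#N)c(C#N)nc21` is built on a different core; the difference between the two cores is not broken down here. In this assay compound 3 gives 1380 nM, which sits within the scatter of compound 1 and compound 2.

Compound 4 `CCN(CC)CCCCn1c(N)c(-c2nc3ccccc3o2)c2nc(C#N)c(C#N)nc21` is not yet measured. It carries diethylamino in place of dimethylamino on a saturated chain carbon, four bonds along the chain from an aromatic nitrogen. Among the measured compounds shown here, this is the same kind of change as the one from compound 1 to compound 2, but the place is not identical: there the amine sat three bonds along the chain from an aromatic nitrogen, here it sits four bonds along. The expected step of a 1.1-fold higher number from compound 3 to compound 4 (0.02 log units; within the scatter) is small, because a 1.0-fold higher number from compound 1 to compound 2 (0.02 log units; within the scatter) was within the scatter. Compound 4 is therefore estimated at 1450 nM in this assay, expected between 800 nM and 2700 nM.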

Compound 4, half-maximal inhibitory concentration: 1980 nM
For compound 4 the middle estimate is 1.4-fold (0.14 log units) below the measured one; low and high end bracket the measured number.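

In this assay, diethylamino in place of dimethylamino gives a 1.4-fold higher number from compound 3 to compound 4 (0.16 log units; within the scatter), and the two cores do not separate on this change: the same change on two cores in this assay, a 1.0-fold higher number (0.02 log units; within the scatter) from compound 1 to compound 2 and a 1.4-fold higher number (0.16 log units; within the scatter) from compound 3 to compound 4, 1.4-fold (0.14 log units) apart, within the scatter of two such steps

Across these two pairs, the change carries from one core to the other with no step beyond the scatter, with the amine three bonds along the chain in one pair and four bonds along in the other. This does not show that the step is identical on both cores, nor does it extend to any core outside these two pairs.

Still open, on these data alone, is whether dipropylamino or a primary amine at the chain end would give a step beyond the scatter. As far as these compounds go, a longer chain carrying the same two amines also remains open.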